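A few compounds are considered here, and "the series" means these few. Any claim that something is new, unique, unknown or untested is made for them only; others in the source may bear on it.

Among the measured compounds shown here, in a physicochemical assay for lipophilicity, at pH 7.4 (on this read-out lower numbers stand for lower lipophilicity and higher numbers for higher lipophilicity), compound 2 `Cc1ccn(-c2ccncc2N2CCC(C(=O)N(C)C)CC2)n1` gives 1.5 and lies within the scatter of compound 1 `O=C(NC1CC1)C1CCN(c2cnccc2-c2ccccn2)CC1` at 1.3 on the only two numbers available. Compound 3 `Cc1cnc(-c2ccncc2N2CCC(C(=O)N(C)C)CC2)s1` carries 5-methyl-1,3-thiazol-2-yl in place of the 3-methyl-1H-pyrazol-1-yl of compound 2 on an aromatic carbon (5-methyl-1,3-thiazol-2-yl in place of 3-methyl-1H-pyrazol-1-yl on an aromatic carbon). For the measured compounds named here, no measured pair shows this change, so the expectation rests on the structural change alone. An upward step of a number 0.50 log units higher from compound 2 to compound 3 (beyond the scatter) is expected in this assay and would lie beyond the scatter. For compound 3 the estimated value is 2 with an expected range (1.6 to 2.4).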

Compound 3, distribution coefficient: 2
Beside the measured number, compound 3's estimate shows no gap at the digits printed, and the stated range covers the measured number.
By their numbers in this assay, from the lowest: compounds 1 and 2 (each within the scatter of the next); then compound 3.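

In this assay, among the compounds shown here, 5-methyl-1,3-thiazol-2-yl in place of 3-methyl-1H-pyrazol-1-yl on this aromatic carbon, opposite the ring nitrogen and ortho to a large group, gives a number 0.50 log units higher from compound 2 to compound 3 (beyond the scatter) and so provides the only readable step at this position. The two groups have equal counts of heavy atoms, hydrogen-bond donors and hydrogen-bond acceptors, and differ in one nitrogen against one sulfur, so those counts alone do not separate them. No available measurement explains the step.

Open, as far as these compounds go, is where an amine or a carboxylic acid at this position would fall on this scale. Also open, from the compounds shown here alone, is whether the same exchange gives a similar step on another core.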